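Trimethoxyphenyl for methylphenyl on a pyrazolopyrimidine chalcone

The source may report more compounds than this note shows. Statements on the series, on what has been measured and on what is new or still open speak of the compounds shown alone.

Measured compounds:
compound 1 `COc1cc(C(=O)/C=C/c2cc(-c3cc(OC)c(OC)c(OC)c3)n3nc(-c4ccccc4)cc3n2)cc(OC)c1OC`, >= 100000 nM
compound 2 `COc1cc(-c2cc(/C=C/C(=O)c3ccc(C)cc3)nc3cc(-c4ccccc4)nn23)cc(OC)c1OC`, 50400 nM
compound 3 `COc1cc(-c2cc(C(=O)/C=C/c3ccc(C)cc3)nc3cc(-c4ccccc4)nn23)cc(OC)c1OC`, 56100 nM

In an ADME assay on HEK293 cells (Homo sapiens) for antiproliferative activity, read by MTT assay, with a stated time of 24 h (a higher number here means a weaker inhibitor, a lower number a stronger inhibitor), compound 2 gives 50400 nM and compound 3 gives 56100 nM; the two are related as (2-(4-methylphenyl)ethenyl)carbonyl in place of 2-((4-methylphenyl)carbonyl)ethenyl on an aromatic carbon, and a 1.1-fold higher number from compound 2 to compound 3 (0.05 log units; within the scatter). For compound 1 the value >= 100000 nM is a limit of this assay and not a number, as the limit of >= 100000 nM in this assay, at which 1 of the 3 values shown sits, records. Compound 1 arises from compound 2 by the change (3,4,5-trimethoxyphenyl in place of 4-methylphenyl on a carbonyl carbon), and the step is an at least 1.9-fold higher number from compound 2 to compound 1 (0.29 log units; that floor lies within the scatter).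

Compound 4 `COc1cc(/C=C/C(=O)c2cc(-c3cc(OC)c(OC)c(OC)c3)n3nc(-c4ccccc4)cc3n2)cc(OC)c1OC` is not yet measured in this assay. It stands to compound 3 as compound 1 stands to compound 2, through (3,4,5-trimethoxyphenyl in place of 4-methylphenyl on a double-bonded chain carbon bound to a double-bonded chain carbon). The change is the same kind of change, not the same: in compound 1 it sits on a carbonyl carbon whose other neighbours are a double-bonded chain carbon, whereas in compound 4 it sits on a double-bonded chain carbon bound to a double-bonded chain carbon.

Compound 4 is therefore expected to follow the step from compound 2 to compound 1, and its step from compound 3 is estimated as a 2.0-fold higher number from compound 3 to compound 4 (0.29 log units; within the scatter), which rests on an at least 1.9-fold higher number from compound 2 to compound 1 (0.29 log units; that floor lies within the scatter) and on the limit that compound 1 reaches. For compound 4 the expected value in this assay is 110000 nM, with a range from 60000 nM to 250000 nM, and it is likely that only a limit will be reported.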

Compound 4, half-maximal inhibitory concentration: 41000 nM
Estimate against measurement, compound 4: 2.7-fold (0.43 log units) above; the whole stated range lies above it.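

In this assay, putting 3,4,5-trimethoxyphenyl in place of 4-methylphenyl gives a 1.4-fold lower number from compound 3 to compound 4 (0.14 log units; within the scatter), and this step does not match the earlier one, so the change did not carry from one core to the other as a fixed step: the same change on two cores in this assay, an at least 1.9-fold higher number (0.29 log units; that floor lies within the scatter) from compound 2 to compound 1 and a 1.4-fold lower number (0.14 log units; within the scatter) from compound 3 to compound 4, at least 2.7-fold (0.43 log units) apart, beyond the scatter of two such steps. The earlier step is known only as a floor, as compound 1 stands at a limit of the assay and not at a number: the limit of >= 100000 nM in this assay, at which 1 of the 4 values shown sits. Taken alone, each step lies within the scatter, so neither shows that the 3,4,5-trimethoxyphenyl group moves the number in either direction on its own core, and with a single pair on each core the gap between the steps gives neither a reason for itself nor a rule for any further core.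

The compounds shown leave open how the step would behave on either core if the entering group were a simple 4-methoxyphenyl, or a phenyl ring carrying an amine or a carboxylic acid. They also leave open whether a longer chain in place of the ethenyl link would keep the two cores apart in this assay.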